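This account rests on a few compounds, and the source may have more. Where it says the series, first, only, none or still open, it means among the compounds named here.

Working notes on the series. In a functional assay on the whole organism with Mus musculus as the target (on this read-out higher numbers stand for larger maximal responses and lower numbers for smaller maximal responses), compound 1 `CCCCCCCCCCn1c(=O)n(C2OC(CO)[C@@H](O)[C@H]2O)c2nc(N)nc(O)c21` gives 0%. Compound 3 `CC1(C)O[C@@H]2[C@H](O1)[C@@H](CO)O[C@H]2n1c(=O)n(C/C=C/c2ccccc2)c2c(O)nc(N)nc21` gives 10% in this assay, a gap to compound 1 that lies within the usual scatter. Compound 2 `C=CCn1c(=O)n([C@H]2CO[C@@H](CO)C2)c2nc(N)nc(O)c21` gives 16% in this assay, a gap to compound 1 that lies beyond the scatter. Compound 4 `Nc1nc(O)c2c(n1)n(C1OC(CO)[C@@H](O)[C@H]1O)c(=O)n2CCN1CCCCC1` has not yet been measured in this assay. It differs from compound 1 in one place: piperidin-1-yl in place of octyl on a saturated chain carbon, two bonds along the chain from an aromatic nitrogen. Within the data shown here, no measured pair shows this change, so no computed step is available for it. The expected step from compound 1 to compound 4 in this assay is a number 8 percentage points higher from compound 1 to compound 4 (within the scatter), a small upward shift not clearly beyond the scatter. For compound 4 the estimate in this assay is 8%, with a range from 0% to 25%.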

Compound 4, largest response reached (reported as maximal response), in percent of the reference or control that the assay uses: 0%
Beside the measured number, compound 4's estimate is 8 percentage points above it; the measured number falls inside the stated range.
By their numbers in this assay, from the lowest: compounds 1, 4, 3 and 2 (each within the scatter of the next, the first and the last beyond it).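

At this saturated chain carbon, two bonds along the chain from an aromatic nitrogen, piperidin-1-yl in place of octyl gives no change at the digits printed from compound 1 to compound 4 (within the scatter) in this assay. Among these compounds, this is the first step read at this place, and it shows that an all-carbon chain and a ring holding one nitrogen give the same printed response here. Nothing available explains this outcome.

Still open, going by these compounds, is whether a carboxylic acid or a morpholine ring at this place would shift the response beyond the scatter. Also open, on these data alone, is whether the same change would read alike on the sugar-like groups of compound 2 or compound 3.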